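This account rests on a few compounds, and the source may have more. Where it says the series, first, only, none or still open, it means among the compounds named here.

- Compound 1 `COc1cc(C(=O)c2sc(-c3ccncc3)cc2N)cc(OC)c1OC`: 110 nM
- Compound 2 `COc1cc(C(=O)c2sc(-c3ccsc3)cc2N)cc(OC)c1OC`: 9.6 nM
- Compound 3 `COc1cccc(-c2cc(N)c(C(=O)c3cc(OC)c(OC)c(OC)c3)s2)c1`: 16 nM

These values come from a functional assay on CCRF-CEM cells (Homo sapiens) for antiproliferative activity; on this read-out lower numbers stand for stronger inhibition and higher numbers for weaker inhibition. Compound 3, at 16 nM, lies within the scatter of compound 2, with a 1.7-fold higher number from compound 2 to compound 3 (0.22 log units; within the scatter), and well under compound 1, with a 6.9-fold lower number from compound 1 to compound 3 (0.84 log units; beyond the scatter). Compound 4 `COc1cc(C(=O)c2sc(-c3cccs3)cc2N)cc(OC)c1OC` differs from compound 3 by thiophen-2-yl in place of 3-methoxyphenyl on an aromatic carbon. The closest evidence is the step of a 1.7-fold higher number from compound 2 to compound 3 (0.22 log units; within the scatter), which exchanges the same 3-methoxyphenyl for thiophen-3-yl and stays within the scatter. The larger step of an 11-fold lower number from compound 1 to compound 2 (1.06 log units; beyond the scatter) starts from pyridin-4-yl, so it bears less directly on this change. No step beyond the scatter is therefore expected, and the expected step is a 1.3-fold lower number from compound 3 to compound 4 (0.12 log units; within the scatter). The estimate for compound 4 is 12 nM, with an expected range of 5 nM to 30 nM.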

Compound 4, half-maximal inhibitory concentration: 9.4 nM
Beside the measured number, compound 4's estimate is 1.3-fold (0.11 log units) above it, within the range that was stated.
By their numbers in this assay, from the lowest: compounds 4, 2 and 3 (each within the scatter of the next); then compound 1.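

On the aromatic carbon next to the ring sulfur, thiophen-2-yl and thiophen-3-yl cannot be told apart, with a 1.0-fold lower number from compound 2 to compound 4 (0.01 log units; within the scatter), so shifting the point of attachment within the thiophene changes nothing measurable here. Thiophen-2-yl also stays within the scatter of 3-methoxyphenyl, with a 1.7-fold lower number from compound 3 to compound 4 (0.23 log units; within the scatter), while the gap to pyridin-4-yl remains clear, with a 12-fold lower number from compound 1 to compound 4 (1.07 log units; beyond the scatter), leaving compound 1 alone apart from the other three. No measurement shown here accounts for this separation.

As far as these compounds go, whether an amine or a carboxylic acid at this position would stay with compound 2, compound 3 and compound 4 or fall toward compound 1 remains open.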